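The source may hold more compounds than are shown below. What is called first, only, known or untested is meant among the compounds shown, and "the series" means these compounds.

Of the compounds shown here, three built on one shared core have been measured in a functional assay on 143B cells (Homo sapiens) for antiproliferative activity, read by MTT assay, with a stated time of 48 h; on this read-out lower numbers stand for stronger inhibition and higher numbers for weaker inhibition. Compound 1 `O=C(Nc1cccc(/C=C/C(=O)c2nc3ccccc3[nH]2)c1)c1ccccc1` gives 8340 nM, compound 2 `O=C(Nc1cccc(/C=C/C(=O)c2nc3ccccc3[nH]2)c1)c1ccc(Cl)cc1` gives 7440 nM, and compound 3 `O=C(/C=C/c1cccc(NC(=O)c2ccccc2Br)c1)c1nc2ccccc2[nH]1` gives 6050 nM, the lowest of the three numbers, although its steps to both others stay within the scatter. The measured steps were all small: a 1.1-fold lower number from compound 1 to compound 2 (0.05 log units; within the scatter), a 1.4-fold lower number from compound 1 to compound 3 (0.14 log units; within the scatter) and a 1.2-fold lower number from compound 2 to compound 3 (0.09 log units; within the scatter). Compound 4 `Cc1ccc(C(=O)Nc2cccc(/C=C/C(=O)c3nc4ccccc4[nH]3)c2)cc1` differs from compound 3 by 4-methylphenyl in place of 2-bromophenyl on a carbonyl carbon. The closest guide is the earlier exchange of one aryl group for another on the same carbonyl carbon, which stayed within the scatter, so no step beyond the scatter is expected in this assay here either. Compound 4 is therefore estimated at 7500 nM, with a range from 4000 nM to 14000 nM. The expected step is a 1.2-fold higher number from compound 3 to compound 4 (0.09 log units; within the scatter).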

Compound 4, half-maximal inhibitory concentration: 6560 nM
Compound 4: middle estimate off by 1.1-fold (0.06 log units), on the high side, within the range that was stated.
By their numbers in this assay, from the lowest: compounds 3, 4, 2 and 1 (each within the scatter of the next).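

In this assay the exchange of 2-bromophenyl for 4-methylphenyl on a carbonyl carbon gives a 1.1-fold higher number from compound 3 to compound 4 (0.04 log units; within the scatter) and puts a ring of carbon only where a bromine-bearing ring stood. Methyl gives a 1.1-fold lower number from compound 2 to compound 4 (0.05 log units; within the scatter) when it replaces chloro and a 1.3-fold lower number from compound 1 to compound 4 (0.10 log units; within the scatter) when it replaces hydrogen, so no aryl exchange at this position among these four compounds goes beyond the scatter. Whether an amine, a carboxylic acid or a longer chain on this aryl ring would do so stays open, and no measurement shown offers a reason for these small steps.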